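A few compounds are considered here, and "the series" means these few. Any claim that something is new, unique, unknown or untested is made for them only; others in the source may bear on it.

Among the compounds with values here, compound 1 `CCC1C(=O)N(C)c2cnc(-n3ccc4cc(C(=O)NC(C)C)ccc43)nc2N1c1ccn(C)n1` is the only compound here with a number: in a functional assay on Huh-7 cells (Homo sapiens) for antiproliferative activity, read by CCK-8 assay, with a stated time of 72 h (a lower number here means a stronger inhibitor of growth, a higher number a weaker inhibitor of growth), compound 1 gives 6740 nM. Compound 2 `CC[C@@H]1C(=O)N(C)c2cnc(-n3ccc4cc(C(=O)NCC(C)C)ccc43)nc2N1C1CCCC1` differs from compound 1 in two places; in this assay compound 2 is reported as "not active" (no number reported), with no number given. Compound 3 `CCC1C(=O)N(C)c2cnc(-n3ccc4cc(C(=O)NCC(C)C)ccc43)nc2N1c1ccn(C)n1` differs from compound 1 in one place: isobutyl in place of isopropyl on an amide-type nitrogen. Within the data shown here, no measured pair isolates this change, so the step in this assay is uncertain; it is expected to be small, leaning toward weaker growth inhibition. Compound 2 also carries the isobutyl amide but cannot fix the step. For compound 3 the estimated value is 9000 nM, ranging from 3500 nM to 25000 nM, an expected step of a 1.3-fold higher number from compound 1 to compound 3 (0.13 log units; within the scatter).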

Compound 3, concentration for 50% growth inhibition: 5070 nM
The estimate for compound 3 lay 1.8-fold (0.25 log units) above the measured number, and the stated range covers the measured number.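

In this assay, isobutyl in place of isopropyl on the amide-type nitrogen gives a 1.3-fold lower number from compound 1 to compound 3 (0.12 log units; within the scatter) for this pair, the first to isolate the change. The two groups therefore cannot be told apart here, and growth inhibition stays in the same range with either one. No supporting measurement offers an explanation for this result. On these data alone, whether a longer chain on this nitrogen, or a chain ending in an amine or a carboxylic acid, would shift the number beyond the scatter remains open.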